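Amide nitrogen substituent: from compound 3 to compound 4

The source may report more compounds than this note shows. Statements on the series, on what has been measured and on what is new or still open speak of the compounds shown alone.

Working notes on the shared core, varied on an amide-type nitrogen. In a functional assay on PC-3 cells (Homo sapiens) for antiproliferative activity, read by MTT assay, with a stated time of 24 h (a higher number here means a weaker inhibitor, a lower number a stronger inhibitor), compound 3 `CCn1c(C(=O)N[C@H](CO)C(C)C)ccc1C(CC)(CC)c1ccc(OCS(=O)(=O)c2ccccc2)c(C)c1` gives 7300 nM, nominally the higher of the two numbers shown, yet the step of a 1.1-fold higher number from compound 1 to compound 3 (0.05 log units; within the scatter) from compound 1 `CCn1c(C(=O)N[C@@H](CC(=O)OC)C(=O)OC)ccc1C(CC)(CC)c1ccc(OCS(=O)(=O)c2ccccc2)c(C)c1`, which gives 6490 nM, is within the scatter. Compound 2 `CCn1c(C(=O)NCCNC(=O)OC(C)(C)C)ccc1C(CC)(CC)c1ccc(OCS(=O)(=O)c2ccccc2)c(C)c1` reports only a limit, > 50000 nM. The step of an at least 6.8-fold lower number from compound 2 to compound 3 (0.83 log units; beyond the scatter) is the larger measured step and rests on (the limit of > 50000 nM in this assay, at which 1 of the 3 values shown sits). Compound 4 `CCn1c(C(=O)N[C@H](CCC(=O)O)C(=O)O)ccc1C(CC)(CC)c1ccc(OCS(=O)(=O)c2ccccc2)c(C)c1` differs from compound 3 as follows: 1,3-dicarboxypropyl in place of 1-(hydroxymethyl)-2-methylpropyl on an amide-type nitrogen. Both measured swaps on this nitrogen bear on it: one within the scatter, one at least modest. The 1,3-dicarboxypropyl group is of a kind not tested here, so a modest weakening is expected, a 2.2-fold higher number from compound 3 to compound 4 (0.34 log units; beyond the scatter). Compound 4 is estimated at 16000 nM, between 5000 nM and 50000 nM.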

Compound 4, half-maximal inhibitory concentration: > 50000 nM
Compound 4: no number, only a limit (the forecaster's own chance of this, stated with the estimate: 30%); middle value at least 3.1-fold (0.49 log units) from the limit.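

In this assay, 1,3-dicarboxypropyl on the amide-type nitrogen gives an at least 6.8-fold higher number from compound 3 to compound 4 (0.83 log units; beyond the scatter) and an at least 7.7-fold higher number from compound 1 to compound 4 (0.88 log units; beyond the scatter), so the match between compound 1 and compound 3 does not extend to this group. Compound 4 is the second compound in the series, after compound 2, to reach a limit rather than give a number, and the step between these two cannot be read: the limit of > 50000 nM in this assay, at which 2 of the 4 values shown sit.

From the compounds shown here alone, whether the two carboxylic acids or the longer chain drives this loss remains open. The 1,3-bis(methoxycarbonyl)propyl group, the dimethyl ester of the same chain, would separate the two.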